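A few compounds are considered here, and "the series" means these few. Any claim that something is new, unique, unknown or untested is made for them only; others in the source may bear on it.

Of the compounds shown here, three from this series have been measured. Compound 1 `COCc1c(C)coc1-c1ccc2c(c1OC)CCCC2(C)C` and compound 2 `CCOc1c(-c2occ(C)c2CO)ccc2c1CCCC2(C)C` both carry a gem-dimethyl-bearing saturated ring on the shared core, while compound 3 `Cc1coc(-c2ccc3c(c2O)CCCC3)c1C(=O)O` lacks those methyls and carries a carboxylic acid on its furan. In a functional assay on DU-145 cells (Homo sapiens) for cytotoxicity, read by sulforhodamine B assay, with a stated time of 3 days (on this read-out higher numbers stand for an effect only at larger amounts of compound and lower numbers for an effect already at smaller amounts), compound 1 gives 17.5 uM, and in this assay compound 2 gives 17.5 uM, the same at the digits shown and within the scatter of each other, so no order between them can be claimed. Compound 3 gives 40.4 uM in this assay, a gap from compound 1 that lies beyond the scatter. Compound 4 `COc1c(-c2occ(C)c2COC(C)=O)ccc2c1CCCC2(C)C` has not yet been measured. It differs from compound 1 in one place: acetyl in place of methyl on an oxygen on a saturated carbon. For the measured compounds named here, no measured pair in this set isolates that change, so the expectation rests on the two numbers already at hand. Given that compound 1 gives 17.5 uM, the step of a 1.0-fold higher number from compound 1 to compound 4 (0.01 log units; within the scatter) is expected to stay within the scatter, in no clear direction. Compound 4 is therefore estimated at 18 uM in this assay, within a range from 8 uM to 40 uM.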

Compound 4, concentration for half-maximal effect: 16.7 uM
Estimate against measurement, compound 4: 1.1-fold (0.03 log units) above; the measured number falls inside the stated range.
By their numbers in this assay, from the lowest: compounds 4, 1 and 2 (each within the scatter of the next); then compound 3.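

For the compounds shown here, the step of acetyl in place of methyl on an oxygen on a saturated carbon can now be read directly for the first time: in this assay it is a 1.0-fold lower number from compound 1 to compound 4 (0.02 log units; within the scatter), within the scatter and in no clear direction. On this read-out, then, methoxymethyl and acetoxymethyl cannot be told apart at this place, although acetyl brings more heavy atoms, a double bond outside aromatic rings and a hydrogen-bond acceptor. No measurement at hand offers an explanation for this result.

The compounds shown leave open whether a different group on that oxygen, such as an amine-bearing chain or a longer acyl chain, would separate from compound 1 beyond the scatter. They also leave open whether the same exchange would read alike on a core lacking the two methyls.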